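The compounds below may be only part of what the source reports. "The series", "measured", "known", "first", "only" and "open" are said of these compounds alone.

Compound 1 `COc1cc(/C=C/C(=O)c2cccc(-n3cc(-c4ccc(Cl)cc4)[nH]c3=O)c2)cc(OC)c1OC` was examined in a functional assay on NCI-H23 cells (Homo sapiens) for inhibition (a lower number here means a stronger inhibitor of growth, a higher number a weaker inhibitor of growth), where compound 1 gives 3560 nM. For the measured compounds named here, the only other compound measured in this assay is compound 2 `O=C(/C=C/c1cccc(O)c1)c1cccc(-n2cc(-c3ccccc3)[nH]c2=O)c1`, and in this assay compound 2 gives 3350 nM. Compound 1 stands at the highest of the two numbers, yet the two values lie within the usual scatter of repeated measurements, so on this evidence the two compounds cannot be told apart.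

Compound 3 `COc1cc(/C=C/C(=O)c2cccc(-n3cc(-c4ccccc4)[nH]c3=O)c2)cc(OC)c1OC` has not yet been measured in this assay. It differs from compound 1 in one place: hydrogen in place of chloro on an aromatic carbon. Going by the values given here, no pair of measured compounds shows this change on its own, so its effect cannot be read from a measured step. Compound 2, which carries a phenyl where compound 1 carries the 4-chlorophenyl, gives a value close to that of compound 1 in this assay, but its other half differs as well, so this is only a hint.

The step from compound 1 to compound 3 is expected to be small and probably not beyond the scatter: a 1.1-fold higher number from compound 1 to compound 3 (0.05 log units; within the scatter). For compound 3 the estimated value in this assay is 4000 nM, expected to fall between 1800 nM and 9000 nM.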

Compound 3, concentration for 50% growth inhibition: 1430 nM
For compound 3 the middle estimate is 2.8-fold (0.45 log units) above the measured one; the measured number lies below the stated range.
By their numbers in this assay, from the lowest: compound 3; then compounds 2 and 1 (each within the scatter of the next).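

Within this assay, the change from 4-chlorophenyl to phenyl can now be read on its own, and a 2.5-fold lower number from compound 1 to compound 3 (0.40 log units; beyond the scatter) is what it gives on the core of compound 1. The chloro at this place, para to a large group, therefore does matter to the number, a step that the earlier comparison of compound 1 with compound 2 could not show, as those two compounds differ in more than one place. No measurement at hand bears on the reason for this step.

The compounds shown leave open whether this step is particular to chloro or would also appear with another group on the same aromatic carbon, such as fluoro, methoxy, an amine or a carboxylic acid. They also leave open whether chloro in place of hydrogen would move the number of compound 2 in the same direction, so the step rests on a single pair and on the core of compound 1 alone.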